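Adding a Methoxy Group to the Fused Ring of Compound 1

A few compounds are considered here, and "the series" means these few. Any claim that something is new, unique, unknown or untested is made for them only; others in the source may bear on it.

Of the compounds shown here, three sharing one core have been measured in a functional assay on HeLa cells (Homo sapiens) for cytotoxicity, read by MTT assay, with a stated time of 48 h; on this read-out lower numbers stand for stronger inhibition and higher numbers for weaker inhibition. Compound 1 `CCOC(=O)c1c(-c2cc3ccccc3oc2=O)nn(-c2ccccc2)c1C(=O)OCC` gives 100000 nM and sits second highest of the three numbers. Compound 2 `CCOC(=O)c1c(-c2cc3ccccc3oc2=O)nn(-c2ccc(OC)cc2)c1C(=O)OCC` gives 90000 nM, and compound 3 `CCOC(=O)c1c(-c2cc3ccccc3oc2=O)nn(-c2ccc(Br)cc2)c1C(=O)OCC` gives 250000 nM. The step of a 1.1-fold lower number from compound 1 to compound 2 (0.05 log units; within the scatter) lies within the scatter, whereas a 2.5-fold higher number from compound 1 to compound 3 (0.40 log units; beyond the scatter) and a 2.8-fold higher number from compound 2 to compound 3 (0.44 log units; beyond the scatter) are modest changes beyond it.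

Compound 4 `CCOC(=O)c1c(-c2cc3cc(OC)ccc3oc2=O)nn(-c2ccccc2)c1C(=O)OCC` has not yet been measured. It differs from compound 1 by methoxy in place of hydrogen on an aromatic carbon, placed on an aromatic carbon of a six-membered aromatic ring of carbon only, part of a fused system of two rings, meta to a fused ring and para to a fused ring. For the measured compounds named here, the only measured step with the same group entering is a 1.1-fold lower number from compound 1 to compound 2 (0.05 log units; within the scatter), which put methoxy on the other, single aromatic ring and stayed within the scatter. Going by the values given here, no measured step touches the fused ring itself, so the expectation leans on that one step. Compound 4 is therefore expected to show no change at the digits printed from compound 1 to compound 4 (within the scatter), essentially no change beyond the scatter, with an estimated value of 100000 nM and a range from 40000 nM to 250000 nM.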

Compound 4, half-maximal inhibitory concentration: 145000 nM
Compound 4: middle estimate off by 1.5-fold (0.16 log units), on the low side, and the stated range covers the measured number.
By their numbers in this assay, from the lowest: compounds 2, 1, 4 and 3 (each within the scatter of the next, the first and the last beyond it).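

Placed on the six-membered aromatic ring of carbon only, part of the fused system, methoxy gives a 1.5-fold higher number from compound 1 to compound 4 (0.16 log units; within the scatter) in this assay. For the compounds shown here, this is the first look at that ring, and the result shows that it can carry methoxy with no change that stands clear of the scatter. The same holds for the methoxy of compound 2, seen in a 1.1-fold lower number from compound 1 to compound 2 (0.05 log units; within the scatter), so in both places where this group enters, the number stays within the scatter of compound 1, and no measurement shown here offers any explanation for this result.

Bromo gave a step beyond the scatter in compound 3, and whether it would do so at this new position remains open. Also open, from the compounds shown here alone, is how an amine or a carboxylic acid would behave there, and whether methoxy on the other carbons of this ring would match compound 4.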